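The compounds below may be only part of what the source reports. "The series", "measured", "known", "first", "only" and "open" are said of these compounds alone.

Measured so far in a functional assay on A2780 cells (Homo sapiens) for antiproliferative activity, read by CellTiter-Glo, with a stated time of 4 days (a higher number here means a weaker inhibitor, a lower number a stronger inhibitor), are two compounds.

- Compound 1 `CCC(=O)NC(C)(C)c1ccc(NC(=O)[C@H]2C[C@@H]2c2cccnc2)cc1` gives 832 nM
- Compound 2 `C[C@H](NC(=O)CC(F)(F)F)c1ccc(NC(=O)[C@H]2C[C@@H]2c2cccnc2)cc1` gives 5 nM

Compound 2 has the lower number of the two, and its gap to compound 1 lies beyond the scatter of repeat measurements. Compound 3 `COCC(=O)N[C@@H](C)c1ccc(NC(=O)[C@H]2C[C@@H]2c2cccnc2)cc1` has not been measured. It carries methoxy in place of trifluoromethyl on a saturated chain carbon bound to a carbonyl carbon. Going by the values given here, no measured pair shows this swap. With compound 2 already at 5 nM a higher number seems likelier than a lower one, so a modest weakening is expected (a 3.0-fold higher number from compound 2 to compound 3 (0.48 log units; beyond the scatter)). Compound 3 is estimated at 15 nM (expected range 4 nM to 60 nM).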

Compound 3, half-maximal inhibitory concentration: 30 nM
The estimate for compound 3 lay 2.0-fold (0.30 log units) below the measured number, and the stated range covers the measured number.
By their numbers in this assay, from the lowest: compound 2; then compound 3; then compound 1.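

In this assay, putting methoxy in place of trifluoromethyl on this saturated chain carbon bound to a carbonyl carbon gives a 6.0-fold higher number from compound 2 to compound 3 (0.78 log units; beyond the scatter), so this place accepts the swap with a modest loss, not a collapse. Changing the whole group on the aromatic carbon counts for more, with a 28-fold lower number from compound 1 to compound 3 (1.44 log units; beyond the scatter) in the other direction. Nothing measured here explains either step.

From the compounds shown here alone, how an amine, a hydroxyl or a longer chain would fare in this place remains open. So does which part of the group on the aromatic carbon carries the large step.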